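Adding a benzyl group to the free hydroxyl of compound 3

A few compounds are considered here, and "the series" means these few. Any claim that something is new, unique, unknown or untested is made for them only; others in the source may bear on it.

Measured compounds:
Compound 1 `O=c1c(Cc2coc3cccc(OCC4CCCCC4)c3c2=O)coc2ccccc12`: in a functional assay on NUGC-3 cells (Homo sapiens) for antiproliferative activity, read by XTT assay (a higher number here means a weaker inhibitor, a lower number a stronger inhibitor), compound 1 gives 3530 nM.
Compound 2 `CC(C)COc1cccc2occ(Cc3coc4ccccc4c3=O)c(=O)c12`: in this assay compound 2 reaches only a limit, > 10000 nM, so no number is known for it.
Compound 3 `O=c1c(Cc2coc3cccc(O)c3c2=O)coc2ccccc12`: in this assay compound 3 gives 3270 nM.

Compound 3, which carries a free hydroxyl on its aromatic ring, has the lowest of the two numbers that are known, but its neighbour compound 1 sits within the scatter of it, as the step of a 1.1-fold lower number from compound 1 to compound 3 (0.03 log units; within the scatter) shows. The value for compound 2 is only a limit (the limit of > 10000 nM in this assay, at which 1 of the 3 values shown sits).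

Compound 4 `O=c1c(Cc2coc3cccc(OCc4ccccc4)c3c2=O)coc2ccccc12` differs from compound 3 in one place: benzyl in place of hydrogen on an oxygen on an aromatic ring. For the measured compounds named here, two measured steps bear on this change, since both replace a group on the same oxygen with hydrogen. Removing the cyclohexylmethyl group gave a 1.1-fold lower number from compound 1 to compound 3 (0.03 log units; within the scatter), no change beyond the scatter, whereas removing the isobutyl group gave an at least 3.0-fold lower number from compound 2 to compound 3 (0.48 log units; beyond the scatter). A benzyl group is a single six-membered ring on one carbon, closer in size to cyclohexylmethyl than to isobutyl, so the expected step of a 1.4-fold higher number from compound 3 to compound 4 (0.14 log units; within the scatter) is small, with a lean toward a higher number. The estimated value for compound 4 is 4500 nM, between 2000 nM and 10000 nM.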

Compound 4, half-maximal inhibitory concentration: 7220 nM
Estimate against measurement, compound 4: 1.6-fold (0.21 log units) below; the measured number falls inside the stated range.
By their numbers in this assay, from the lowest: compounds 3 and 1 (each within the scatter of the next); then compound 4. At a limit, above all of these: compound 2.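

The free hydroxyl of compound 3 can't be replaced by just any ring-bearing group at no cost in this assay: unlike the cyclohexylmethyl group of compound 1, which left the number within the scatter of compound 3, benzyl gives a 2.2-fold higher number from compound 3 to compound 4 (0.34 log units; beyond the scatter). The nature of the ring also matters, as phenyl in place of cyclohexyl on the same saturated chain carbon gives a 2.0-fold higher number from compound 1 to compound 4 (0.31 log units; beyond the scatter), so a six-membered ring at this place does not by itself keep the number low, and the aromatic ring stands on the weaker side of the saturated one here. The step of an at least 1.3-fold lower number from compound 2 to compound 4 (0.14 log units; that floor lies within the scatter) does not settle how compound 4 ranks against compound 2, since compound 2 stands only at a limit: the limit of > 10000 nM in this assay, at which 1 of the 4 values shown sits.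

On these data alone, whether an amine or a carboxylic acid at the end of the group on this oxygen, or a longer chain carrying the phenyl ring, would bring the number below that of compound 3 stays open. The compounds shown also give no reason for the gap between the cyclohexyl and phenyl rings, only its size.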